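Methyl for Fluoro in a Trimethoxyphenyl Triazole Series

The source may hold more compounds than are shown below. What is called first, only, known or untested is meant among the compounds shown, and "the series" means these compounds.

Of the compounds shown here, three have been tested in a functional assay on A549 cells (Homo sapiens) for cytotoxicity, read by MTT assay, with a stated time of 48 h; a lower number here means a stronger inhibitor, a higher number a weaker inhibitor. Compound 1 `COc1cc(COCc2cn(Cc3cc(-c4ccc(F)cc4)cnc3Cl)nn2)cc(OC)c1OC` gives 50600 nM in this assay. Compound 2 `COc1cc(-c2cc(COCc3cn(Cc4cc(-c5ccc(F)cc5)cnc4Cl)nn3)on2)cc(OC)c1OC` gives 40600 nM, the second highest of the three numbers, within the scatter of compound 1 and beyond the scatter above compound 3. Compound 3 `COc1cc(C2=NOC(COCc3cn(Cc4cc(-c5ccc(C)cc5)cnc4Cl)nn3)C2)cc(OC)c1OC`, which carries a differently built middle part, gives 11500 nM in this assay.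

Compound 4 `COc1cc(-c2cc(COCc3cn(Cc4cc(-c5ccc(C)cc5)cnc4Cl)nn3)on2)cc(OC)c1OC` has not been measured. It differs from compound 2 by methyl in place of fluoro on an aromatic carbon. Among the compounds with values here, the only measured compound bearing the 4-methylphenyl group is compound 3, whose lower number cannot be attributed to that group alone, since its middle part also differs.

Compound 4 is expected to give about 28000 nM in this assay, within a range of 12000 nM to 65000 nM. The expected step of a 1.5-fold lower number from compound 2 to compound 4 (0.16 log units; within the scatter) is a modest one toward a lower number, of a size that may not exceed the scatter, because compound 2 at 40600 nM and compound 3 at 11500 nM leave the effect of the methyl group uncertain.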

Compound 4, half-maximal inhibitory concentration: 30600 nM
Compound 4: the middle estimate sits 1.1-fold (0.04 log units) below what was measured, within the range that was stated.
By their numbers in this assay, from the lowest: compound 3; then compounds 4, 2 and 1 (each within the scatter of the next).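

In this assay the step from 4-fluorophenyl to 4-methylphenyl, a 1.3-fold lower number from compound 2 to compound 4 (0.12 log units; within the scatter), shows that on the core of compound 2 this position takes methyl in place of fluoro without a difference that can be told from the scatter. The two compounds with the 4-methylphenyl group also stand apart in their printed values: compound 3 gives 11500 nM and compound 4 gives 30600 nM, so that group alone does not carry the number of compound 3 over to the core of compound 2. Nothing measured here offers an explanation for how these values fall.

What the compounds shown leave open is whether a clearly different group at this position, such as an amine or a carboxylic acid, would move the number beyond the scatter. Going by these compounds, it also remains open how 4-fluorophenyl would read on the middle part of compound 3.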